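Fluorine Added to the Aromatic Ring of Compound 1

The source may report more compounds than this note shows. Statements on the series, on what has been measured and on what is new or still open speak of the compounds shown alone.

Compound 1 `C[C@]1(CO)OC[C@@H](n2ccc(N)nc2=O)O1` is tested in a functional assay on L1210 cells (Mus musculus) for inhibition (on this read-out higher numbers stand for weaker inhibition and lower numbers for stronger inhibition), where compound 1 gives 45000 nM. Its counterpart drawn without stereo configuration, compound 2 `CC1(CO)OCC(n2ccc(N)nc2=O)O1`, gives 50000 nM in this assay; the step of a 1.1-fold higher number from compound 1 to compound 2 (0.05 log units; within the scatter) lies within the scatter, so the two values stand side by side. Compound 3 `C[C@]1(CO)OC[C@@H](n2cc(F)c(N)nc2=O)O1` differs from compound 1 by fluoro in place of hydrogen on an aromatic carbon. For the measured compounds named here, no measured step touches this kind of change, so the step of a 1.8-fold lower number from compound 1 to compound 3 (0.26 log units; within the scatter) is an expectation with wide room in either direction. Compound 3 is expected to give 25000 nM, estimated between 4000 nM and 150000 nM.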

Compound 3, half-maximal inhibitory concentration: > 100000 nM
Compound 3: no number, only a limit (the forecaster's own chance of this, stated with the estimate: 10%); middle value at least 4.0-fold (0.60 log units) from the limit.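

In this assay compound 3 gives > 100000 nM, which is a limit of the assay and not a number. Even so, fluoro in place of hydrogen on this aromatic carbon, ortho to the amino group, weakens inhibition, with an at least 2.2-fold higher number from compound 1 to compound 3 (0.34 log units; beyond the scatter). For the compounds shown here, compounds 1 and 2 differ only in how their stereo elements are drawn, so this is the first sign that inhibition responds to a change at this ring position.

On these data alone, whether chloro, methyl or an amine at the same carbon would also weaken inhibition stays open. As far as these compounds go, how far the loss with fluoro extends past the limit also stays open.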